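Swapping bromo for nitro on a shared core

The source may report more compounds than this note shows. Statements on the series, on what has been measured and on what is new or still open speak of the compounds shown alone.

Three compounds share one core. Compound 3 `Cc1ccc(-n2c(Nc3nc(-c4ccc(Br)cc4)cs3)n[nH]c2=S)cc1` gives 300 mg/kg in a functional assay on the whole organism (strain Swiss albino) for inhibition, with Mus musculus as the target, with a stated time of 0.5 h (on this read-out higher numbers stand for an effect only at larger amounts of compound and lower numbers for an effect already at smaller amounts), level with compound 2 `Cc1ccc(-n2c(Nc3nc(-c4ccccc4)cs3)n[nH]c2=S)cc1`, which gives 300 mg/kg; together they stand highest of the three. Compound 1 `Cc1ccccc1-n1c(Nc2nc(-c3ccc([N+](=O)[O-])cc3)cs2)n[nH]c1=S` gives 100 mg/kg, a lower number beyond the scatter. Compound 4 `Cc1ccc(-n2c(Nc3nc(-c4ccc([N+](=O)[O-])cc4)cs3)n[nH]c2=S)cc1` is not yet measured; its change from compound 3 is nitro in place of bromo on an aromatic carbon. Among the measured compounds shown here, the only measured step, no change at the digits printed from compound 2 to compound 3 (within the scatter), concerns a different group and bears on this change only loosely. Compound 1, which carries the same nitro group, gives 100 mg/kg, the lowest number, so a move toward smaller doses is expected. Compound 4 is therefore expected to give 150 mg/kg, between 70 mg/kg and 300 mg/kg. The expected step is a 2.0-fold lower number from compound 3 to compound 4 (0.30 log units; within the scatter).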

Compound 4, minimum effective dose: 300 mg/kg
For compound 4 the middle estimate is 2.0-fold (0.30 log units) below the measured one, and the stated range covers the measured number.
By their numbers in this assay, from the lowest: compound 1; then compounds 2, 3 and 4 (each within the scatter of the next).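

In this assay the nitro group on this aromatic carbon gives no change at the digits printed from compound 3 to compound 4 (within the scatter) and no change at the digits printed from compound 2 to compound 4 (within the scatter) so hydrogen, bromo and nitro cannot be told apart here. With nitro held fixed, 4-methylphenyl in place of 2-methylphenyl on an aromatic nitrogen gives a 3.0-fold higher number from compound 1 to compound 4 (0.48 log units; beyond the scatter) so the lower number of compound 1 goes with its 2-methylphenyl group, not with nitro alone. Nothing measured here gives a reason for either result.

From the compounds shown here alone, whether an amine or a carboxylic acid on this carbon would shift the number remains open. So does whether the 2-methylphenyl group would give the lower number with bromo or hydrogen in place of nitro.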